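Swapping 3-hydroxynaphthalen-2-yl for 3-methoxyphenyl on a carbonyl carbon

A few compounds are considered here, and "the series" means these few. Any claim that something is new, unique, unknown or untested is made for them only; others in the source may bear on it.

In a functional assay on M14 cells (Homo sapiens) for inhibition, read by sulforhodamine B assay, with a stated time of 48 h (on this read-out higher numbers stand for weaker inhibition of growth and lower numbers for stronger inhibition of growth), compound 1 (`COc1cccc(C(=O)NNC(=O)c2ccc3[nH]c(-c4ccc([N+](=O)[O-])o4)nc3c2)c1`) gives 7.81 ug/mL while compound 2 (`O=C(NNC(=O)c1cc2ccccc2cc1O)c1ccc2[nH]c(-c3ccc([N+](=O)[O-])s3)nc2c1`) gives 62.5 ug/mL as the higher of the two numbers, a gap beyond the scatter. Compound 3 (`COc1cccc(C(=O)NNC(=O)c2ccc3[nH]c(-c4ccc([N+](=O)[O-])s4)nc3c2)c1`) differs from compound 2 by having 3-methoxyphenyl in place of 3-hydroxynaphthalen-2-yl on a carbonyl carbon. For the measured compounds named here, compound 1, which also bears 3-methoxyphenyl on a carbonyl carbon, stands at 7.81 ug/mL and is the only guide to the expectation. The expected step of a 4.0-fold lower number from compound 2 to compound 3 (0.60 log units; beyond the scatter) in this assay is downward and beyond the scatter. Compound 3 is estimated at 15.6 ug/mL (expected range 5 ug/mL to 62.5 ug/mL).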

Compound 3, concentration for 50% growth inhibition: 15.6 ug/mL
Compound 3: the middle estimate sits on the measured number at the digits printed; low and high end bracket the measured number.
By their numbers in this assay, from the lowest: compounds 1 and 3 (each within the scatter of the next); then compound 2.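

In this assay the swap to 3-methoxyphenyl from 3-hydroxynaphthalen-2-yl on the carbonyl carbon gives a 4.0-fold lower number from compound 2 to compound 3 (0.60 log units; beyond the scatter) and shows that this position responds to the group it carries. With 3-methoxyphenyl held fixed, 5-nitrothiophen-2-yl in place of 5-nitrofuran-2-yl on an aromatic carbon gives a 2.0-fold higher number from compound 1 to compound 3 (0.30 log units; within the scatter) and so does not separate the two rings in this pair. No measurement on hand explains either step.

From the compounds shown here alone, whether a carboxylic acid or an amine on the phenyl ring at this carbonyl carbon would shift the number remains open. So does whether 3-hydroxynaphthalen-2-yl costs as much alongside 5-nitrofuran-2-yl.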